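Efficacy notes on a thiazole-linked aniline acid series

This account rests on a few compounds, and the source may have more. Where it says the series, first, only, none or still open, it means among the compounds named here.

Measured compounds:
- compound 1 `Cc1nc(-c2ccc(C(F)(F)F)cc2)sc1CNc1ccc(/C=C/C(=O)O)cc1`: 95%
- compound 2 `O=C(O)CSc1ccc(NCc2cccc(Oc3ccccc3)c2)cc1`: 84%

In a functional assay on CHO cells for agonist activity at Free fatty acid receptor 1 (Homo sapiens), read by a luciferase reporter (on this read-out lower numbers stand for smaller maximal responses and higher numbers for larger maximal responses), compound 1 gives 95%, the highest of the two numbers recorded. The nearest value belongs to compound 2, which in this assay gives 84%, a gap that lies beyond the usual scatter, so compound 1 reaches the larger maximal response of the pair. Within the data shown here, the two compounds share the aniline acid motif but differ in several places at once, so no single step between them can be read.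

Compound 3 `Cc1nc(-c2ccc(C(F)(F)F)cc2)sc1CNc1ccc(C(C)CC(=O)O)cc1` is not yet measured. It keeps the whole core of compound 1 and differs only at the acid side: 1-(carboxymethyl)ethyl in place of 2-carboxyethenyl on an aromatic carbon. The change sits on an aromatic carbon of a six-membered aromatic ring of carbon only, para to a large group.

Among the measured compounds shown here, no measured step of this kind exists in the set. Since compound 1 already gives 95%, little room remains upward; a small downward step, near the edge of the scatter, is expected from compound 1 to compound 3 a number 10 percentage points lower from compound 1 to compound 3 (within the scatter). For compound 3 the expected value in this assay is 85%, between 65% and 105%.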

Compound 3, largest response reached (reported as percent of maximum), in percent of the reference or control that the assay uses: 109%
Estimate against measurement, compound 3: 24 percentage points below, and the stated range ends below it.
By their numbers in this assay, from the lowest: compound 2; then compound 1; then compound 3.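

In this assay, the acid side of the core of compound 1 proves open to change: 1-(carboxymethyl)ethyl in place of 2-carboxyethenyl, on an aromatic carbon para to a large group, gives a number 14 percentage points higher from compound 1 to compound 3 (beyond the scatter). For this pair, the carbon-carbon double bond of 2-carboxyethenyl is therefore not needed for a large maximal response, and the 95% of compound 1 does not mark the upper end of what the series reaches at this position. Nothing available here bears on the reason for this step.

The compounds shown leave open whether an unbranched 2-carboxyethyl chain, a shorter carboxymethyl group or a longer acid chain at this place would keep the response of compound 3, and whether a tetrazole or an amide could stand in for the carboxylic acid. From the compounds shown here alone, compound 2 differs from compound 1 and compound 3 in several places at once, so its steps to them cannot be read, and whether the same change would carry over to its structure also remains open.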